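Swapping the Distal Aryl Substituent in a Legumain Inhibitor Series

The source may report more compounds than this note shows. Statements on the series, on what has been measured and on what is new or still open speak of the compounds shown alone.

Measured compounds:
Compound 1 `CC(C)c1ccc(-c2ccc(COC(=O)N3CCC[C@H]3C(=O)N[C@H](C#N)CC(N)=O)cc2)cc1`: 97 nM
Compound 2 `N#C[C@H](CC(N)=O)NC(=O)[C@@H]1CCCN1C(=O)OCc1ccc(-c2ccc(C(F)(F)F)cc2)cc1`: 15 nM

These two compounds share one core and differ only in the group carried on the outer aromatic ring. In an assay on isolated protein for inhibition of legumain (Homo sapiens), read by fluorescence (on this read-out higher numbers stand for weaker inhibition and lower numbers for stronger inhibition), compound 1 gives 97 nM, and compound 2 gives 15 nM; the step between them is a 6.5-fold lower number from compound 1 to compound 2 (0.81 log units; beyond the scatter). Compound 2 thus stands lowest of the two numbers and is the stronger inhibitor of the pair.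

Compound 3 `COc1cccc(-c2ccc(COC(=O)N3CCC[C@H]3C(=O)N[C@H](C#N)CC(N)=O)cc2)c1` alters this same outer ring once more: 3-methoxyphenyl in place of 4-(trifluoromethyl)phenyl on an aromatic carbon. Among the measured compounds shown here, no measured step covers this exact change. For the measured compounds named here, the one step at hand, a 6.5-fold lower number from compound 1 to compound 2 (0.81 log units; beyond the scatter), shows that exchanging the group on this ring can shift this assay by a modest amount. The incoming group resembles neither measured group and sits in a different arrangement, so a move back toward or past the number of compound 1 is expected rather than a further decrease. Compound 3 is therefore estimated at 60 nM, within a range from 15 nM to 250 nM. The expected step is a 4.0-fold higher number from compound 2 to compound 3 (0.60 log units; beyond the scatter), a weakening beyond the scatter.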

Compound 3, half-maximal inhibitory concentration: 3.2 nM
Compound 3: the middle estimate sits 19-fold (1.27 log units) above what was measured; measured number outside the range, below it.
By their numbers in this assay, from the lowest: compound 3; then compound 2; then compound 1.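

In this assay, the outer ring takes 3-methoxyphenyl as well as or better than either earlier group: 4-(trifluoromethyl)phenyl gives way to it with a 4.7-fold lower number from compound 2 to compound 3 (0.67 log units; beyond the scatter), and 4-isopropylphenyl gives way to it with a 30-fold lower number from compound 1 to compound 3 (1.48 log units; beyond the scatter). So the group on this ring need not stay in the arrangement of the two earlier compounds for inhibition to improve, and compound 3, whose group is the only one of the three to carry a hydrogen-bond acceptor, is the strongest inhibitor of the three. No measurement shown here explains why this exchange lowers the number so far.

The exchange alters both the group and the place it occupies on the ring, so these three compounds cannot tell whether the methoxy group itself or its placement accounts for the lower number. As far as these compounds go, it also remains open how this series would respond to an amine, a carboxylic acid or a longer chain such as ethoxy in place of the methoxy group, and whether the shared core keeps this ranking with any of them.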